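The source may report more compounds than this note shows. Statements on the series, on what has been measured and on what is new or still open speak of the compounds shown alone.

In a functional assay for antagonist activity at metabotropic glutamate receptor 5 (Rattus norvegicus) (on this read-out lower numbers stand for stronger inhibition and higher numbers for weaker inhibition), compound 1 `N#Cc1ccccc1-c1cc(F)cc(-n2nnc(-c3ccccn3)n2)c1` gives 6 nM, and compound 2 `Nc1ccccc1-c1cc(F)cc(-n2nnc(-c3ccccn3)n2)c1` gives 8 nM. Compound 2 thus carries the higher of the two numbers, though the step of a 1.3-fold higher number from compound 1 to compound 2 (0.12 log units; within the scatter) lies within the scatter. Compound 3 `Fc1cc(-c2ccccn2)cc(-n2nnc(-c3ccccn3)n2)c1` differs from compound 2 by pyridin-2-yl in place of 2-aminophenyl on an aromatic carbon. For the measured compounds named here, the one measured step changed only the group on that same ring and gave no shift beyond the scatter, so a step of similar modest size, without a clear direction, is expected for a 1.3-fold higher number from compound 2 to compound 3 (0.10 log units; within the scatter). Compound 3 is therefore estimated at 10 nM, with a range from 3 nM to 40 nM.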

Compound 3, half-maximal inhibitory concentration: 39 nM
Estimate against measurement, compound 3: 3.9-fold (0.59 log units) below; the range from low to high includes it.
By their numbers in this assay, from the lowest: compounds 1 and 2 (each within the scatter of the next); then compound 3.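

With pyridin-2-yl in place of 2-aminophenyl, the shared core gives a 4.9-fold higher number from compound 2 to compound 3 (0.69 log units; beyond the scatter) and with it in place of 2-cyanophenyl gives a 6.5-fold higher number from compound 1 to compound 3 (0.81 log units; beyond the scatter) in this assay on this same carbon. So this position does respond to its group: 2-cyanophenyl and 2-aminophenyl sat within the scatter of each other, whereas pyridin-2-yl moves the number beyond it. Nothing available explains this rise. Still open, from the compounds shown here alone, is whether the ring nitrogen or the loss of the phenyl substituent matters more; plain phenyl, or pyridin-2-yl carrying an amine or a nitrile, would separate the two.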